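A Methyl Added to the Core of Compound 1

A few compounds are considered here, and "the series" means these few. Any claim that something is new, unique, unknown or untested is made for them only; others in the source may bear on it.

compound 1 `Cc1nnc(SCc2cc(=O)c3ccccc3o2)s1` — > 25000 nM
compound 2 `Nc1nnc(SCc2cc(=O)c3ccccc3o2)s1` — > 25000 nM

In a functional assay on MCF7 cells (Homo sapiens) for cytotoxicity, read by MTT assay, with a stated time of 72 h (on this read-out higher numbers stand for weaker inhibition and lower numbers for stronger inhibition), compound 1 gives > 25000 nM, which is a limit of the assay and not a number. Compound 2 likewise gives > 25000 nM, again only a limit. The step that the two limits leave unreadable from compound 1 to compound 2 is therefore unreadable, since both ends sit at the limit of > 25000 nM in this assay, at which 2 of the 2 values shown sit. On the numbers shown, compound 1 stands only at that limit, with no measured inhibition to compare.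

Compound 3 `Cc1ccc2oc(CSc3nnc(C)s3)cc(=O)c2c1` differs from compound 1 by methyl in place of hydrogen on an aromatic carbon. The one measured step gives no readable size, so nothing shown points to a change in either direction. With compound 1 at a limit, the expected step in this assay is a step that the limit leaves unreadable from compound 1 to compound 3, meaning most likely another limit rather than a number beyond the scatter. The estimate for compound 3 in this assay is 35000 nM, with a range from 10000 nM to 120000 nM.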

Compound 3, half-maximal inhibitory concentration: > 25000 nM
Compound 3 ended at the assay's limit; the forecaster's own chance of this, stated with the estimate: 85%; the middle value does not contradict the limit.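

Compound 3 gives > 25000 nM in this assay, again a limit and not a number, so no size can be read for its step from compound 1. The compounds shown leave open whether methyl in place of hydrogen changes cytotoxicity at all: the limit of > 25000 nM in this assay, at which 3 of the 3 values shown sit.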